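This account rests on a few compounds, and the source may have more. Where it says the series, first, only, none or still open, it means among the compounds named here.

In an ADME assay (liver) for metabolic stability, with Liver microsome (Rattus norvegicus) as the target, using microsomes and NADPH, with a stated time of 30 min (on this read-out lower numbers stand for slow clearance and higher numbers for fast clearance), compound 1 (`CC#CCC(O)(c1ccc(N2CCN(S(=O)(=O)c3ccc(N)nc3)C[C@@H]2C#CC)cc1)C(F)(F)F`) gives 115 mL.min-1.g-1. Compound 2 (`CC#C[C@H]1CN(S(=O)(=O)c2ccc(N)nc2)CCN1c1ccc(S(C)(=N)=O)cc1`) gives < 14 mL.min-1.g-1, which is a limit of the assay and not a number. That places compound 2 at the limit of < 14 mL.min-1.g-1 in this assay, at which 1 of the 2 values shown sits. Among the measured compounds shown here, the one measured step is an at least 8.2-fold lower number from compound 1 to compound 2 (0.91 log units; beyond the scatter), and it lies beyond the scatter. Compound 3 (`CC#C[C@H]1CN(S(=O)(=O)c2ccc(N)nc2)CCN1c1ccc([S+](C)[O-])cc1`) differs from compound 2 in a single group, on an aromatic carbon of a six-membered aromatic ring of carbon only, para to a large group: a group of 3 heavy atoms (1 carbon, 1 oxygen, 1 sulfur; no ring) in place of a group of 4 heavy atoms (1 carbon, 1 nitrogen, 1 oxygen, 1 sulfur; no ring), on an aromatic carbon. Only the measured step bears on this change, and it is a weak guide. It took out a group of 10 heavy atoms, whereas the new change only puts a group of 3 heavy atoms in place of a group of 4 heavy atoms. A change of the size of an at least 8.2-fold lower number from compound 1 to compound 2 (0.91 log units; beyond the scatter) is therefore not expected here. The expected move is a number no lower from compound 2 to compound 3 (the limit leaves the size open), small, not clearly beyond the scatter, and more likely upward since the starting point is a limit. In this assay the estimate for compound 3 is 14 mL.min-1.g-1, with an expected range of 7 mL.min-1.g-1 to 35 mL.min-1.g-1.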

Compound 3, intrinsic clearance in microsomes: 17 mL.min-1.g-1
For compound 3 the middle estimate is 1.2-fold (0.08 log units) below the measured one; low and high end bracket the measured number.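

In this assay, putting the group of 3 heavy atoms in place of the group of 4 heavy atoms, on an aromatic carbon para to a large group, gives an at least 1.2-fold higher number from compound 2 to compound 3 (0.08 log units; that floor lies within the scatter). The size of that step stays open because compound 2 stands at a limit of the assay and not at a number: the limit of < 14 mL.min-1.g-1 in this assay, at which 1 of the 3 values shown sits. Compound 3 adds a true number for a small group at this place, and against the group of 10 heavy atoms the step reads a 6.8-fold lower number from compound 1 to compound 3 (0.83 log units; beyond the scatter), so a lower number than that of compound 1 now holds for both small groups shown, with no compound here going against it.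

Both small groups carry sulfur and oxygen, so the compounds shown leave open whether a lower number needs those atoms or only a small group, a question that a methoxy group or an amine at the same place would address. They also leave open how far the nitrogen of the group in compound 2 matters, as the true gap between the two small groups cannot be read.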